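The source may hold more compounds than are shown below. What is called first, only, known or untested is meant among the compounds shown, and "the series" means these compounds.

Measured in a functional assay on AGS cells (Homo sapiens) for inhibition, read by reporter gene assay; on this read-out higher numbers stand for weaker inhibition and lower numbers for stronger inhibition:
Compound 1 `CC(C)(C)c1ccc(OCC(=O)Nc2cccc(C(=O)O)c2)cc1`: 9500 nM
Compound 2 `CC(=O)c1ccc(OCC(=O)Nc2cccc(C(=O)O)c2)cc1`: > 30000 nM (a limit)

For the measured compounds named here, compound 1 holds the only actual number so far. The value of compound 2 is a limit. Going by the values given here, the single measured step, an at least 3.1-fold higher number from compound 1 to compound 2 (0.49 log units; beyond the scatter), puts acetyl in place of tert-butyl and lies beyond the scatter. On these data alone, it ends at the limit of > 30000 nM in this assay, at which 1 of the 2 values shown sits, so its true size remains open.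

Next is compound 3 `O=C(COc1ccc(-c2cccs2)cc1)Nc1cccc(C(=O)O)c1`, with thiophen-2-yl in place of tert-butyl on an aromatic carbon. The acetyl step concerns the same aromatic carbon but a different incoming group, so it bears only loosely on this change. The expectation therefore rests mainly on compound 1 at 9500 nM, and no step beyond the scatter is expected in this assay. The estimate means a 1.4-fold lower number from compound 1 to compound 3 (0.13 log units; within the scatter). Compound 3 is expected at 7000 nM, with an estimated range of 2500 nM to 25000 nM.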

Compound 3, half-maximal inhibitory concentration: > 30000 nM
Compound 3: no number, only a limit (the forecaster's own chance of this, stated with the estimate: 15%); middle value at least 4.2-fold (0.63 log units) away from the limit.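

In this assay, thiophen-2-yl in place of tert-butyl on the same aromatic carbon gives an at least 3.1-fold higher number from compound 1 to compound 3 (0.49 log units; beyond the scatter), so a ring-bearing replacement also moves the read-out beyond the scatter towards weaker inhibition. Compound 3 gives > 30000 nM, which is a limit. Of the three groups shown on this carbon, only tert-butyl gives an actual number, and the step between the limits of compound 2 and compound 3 cannot be read: the limit of > 30000 nM in this assay, at which 2 of the 3 values shown sit.

On these data alone, the true size of the steps away from tert-butyl remains open, as does whether the acetyl and thiophen-2-yl groups differ at all in this read-out. Also open, as far as these compounds go, is whether isopropyl, cyclohexyl or an amine on this carbon would give a number rather than a limit.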